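Substituent swap on the benzyl arm: compound 3

The compounds below may be only part of what the source reports. "The series", "measured", "known", "first", "only" and "open" are said of these compounds alone.

Compound 2 `COC(=O)CC[C@H](C(=O)NO)N(Cc1ccc(C(F)(F)F)cc1)S(=O)(=O)c1ccc(OC)cc1` gives, in an assay on isolated protein with bone morphogenetic protein 1 (Homo sapiens) as the target (a higher number here means a weaker inhibitor, a lower number a stronger inhibitor), a value that is a limit of the assay, > 40000 nM. Compound 1 `COC(=O)CC[C@H](C(=O)NO)N(Cc1ccc(Br)cc1)S(=O)(=O)c1ccc(OC)cc1` carries bromo in place of trifluoromethyl, and in this assay compound 1 likewise reaches only a limit, > 40000 nM. The step that the two limits leave unreadable from compound 1 to compound 2 is therefore unreadable, since both values sit at the same limit (the limit of > 40000 nM in this assay, at which 2 of the 2 values shown sit). Compound 3 `COC(=O)CC[C@H](C(=O)NO)N(Cc1ccc(OC)cc1)S(=O)(=O)c1ccc(OC)cc1` differs from compound 2 by methoxy in place of trifluoromethyl on an aromatic carbon. Within the data shown here, no measured step bears on this change: the single step yields neither a size nor a direction, and both measured values are limits rather than numbers. Among the measured compounds shown here, the expectation for compound 3 in this assay is accordingly no step that can be read beyond the scatter, a number no higher from compound 2 to compound 3 (the limit leaves the size open), with a further limit the most likely outcome. Compound 3 is estimated at 40000 nM, within 10000 nM to 200000 nM.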

Compound 3, inhibition constant: 15000 nM
Compound 3: the middle estimate sits 2.7-fold (0.43 log units) above what was measured; the range from low to high includes it.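

Methoxy in place of trifluoromethyl gives an at least 2.6-fold lower number from compound 2 to compound 3 (0.42 log units; beyond the scatter) in this assay, and methoxy in place of bromo gives an at least 2.6-fold lower number from compound 1 to compound 3 (0.42 log units; beyond the scatter). Among these compounds, compound 3 is thus the first compound here with a number rather than a limit, at 15000 nM, so the substituent on this aromatic carbon of the benzyl arm can shift the read-out beyond the scatter. Both other compounds remain at a limit of the assay: the limit of > 40000 nM in this assay, at which 2 of the 3 values shown sit.

From the compounds shown here alone, the full size of both steps stays open, since each starts from a limit, and the two non-methoxy compounds cannot be ordered against each other. Also open, going by these compounds, is whether the lower number is particular to methoxy or extends to a hydroxyl, an amine or a longer ether chain such as ethoxy at this position.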